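The source may report more compounds than this note shows. Statements on the series, on what has been measured and on what is new or still open speak of the compounds shown alone.

Compound 1, `Oc1cccc(-c2cc(-c3ccco3)cc(-c3ccccc3O)n2)c1`, compound 2, `Oc1cccc(-c2cc(-c3ccco3)cc(-c3cccc(O)c3)n2)c1`, and compound 3, `Oc1ccccc1-c1cc(-c2ccccn2)cc(-c2ccccc2O)n1`, have been measured in a functional assay on HCT-15 cells (Homo sapiens) for cytotoxicity, read by CCK-8 assay (on this read-out lower numbers stand for stronger inhibition and higher numbers for weaker inhibition), while compound 4, `Oc1cccc(-c2cc(-c3ccccn3)cc(-c3ccccc3O)n2)c1`, has not. For compound 1 this assay gives only a limit, > 50000 nM. Compound 2 gives 1890 nM in this assay. The change between them, (3-hydroxyphenyl in place of 2-hydroxyphenyl on an aromatic carbon), made a step of an at least 26-fold lower number from compound 1 to compound 2 (1.42 log units; beyond the scatter). For compound 3 this assay again gives only a limit, > 50000 nM, so compound 3 shares the limit of > 50000 nM in this assay, at which 2 of the 3 values shown sit, with compound 1. How the core of compound 3 differs from the core of compound 1 is not broken down here.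

Compound 4 arises from compound 3 by the same kind of change, (3-hydroxyphenyl in place of 2-hydroxyphenyl on an aromatic carbon), but the place is not the same: here the carbon is meta to a 2-hydroxyphenyl group and meta to a pyridin-2-yl group, whereas in compound 2 it is meta to a 3-hydroxyphenyl group and meta to a furan-2-yl group. Since compound 3 sits at a limit, the step from compound 3 to compound 4 is expected to be an at least 6.2-fold lower number from compound 3 to compound 4 (0.79 log units; beyond the scatter), resting on the step seen in compound 1 and compound 2, an at least 26-fold lower number from compound 1 to compound 2 (1.42 log units; beyond the scatter). Compound 4 is therefore estimated at 8000 nM in this assay, between 1500 nM and 50000 nM.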

Compound 4, half-maximal inhibitory concentration: > 50000 nM
Compound 4: only a limit was reported (the forecaster's own chance of this, stated with the estimate: 35%); at least 6.2-fold (0.79 log units) between middle value and limit.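

In this assay compound 4 gives only a limit, > 50000 nM, so neither the step from compound 3 nor the step from compound 1 to compound 4 can be read. Compound 4 thus sits at the shared limit: the limit of > 50000 nM in this assay, at which 3 of the 4 values shown sit.

The compounds shown leave open whether 3-hydroxyphenyl in place of 2-hydroxyphenyl changes the read-out at all when a pyridin-2-yl group replaces the furan-2-yl group.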